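Series notes: hydroxyphenyl and halogenated aryl groups on the shared core

The source may hold more compounds than are shown below. What is called first, only, known or untested is meant among the compounds shown, and "the series" means these compounds.

Two compounds of the series have been run in an assay on HeLa cells for inhibition of Kinesin-like protein KIF15 (Homo sapiens), read by microscopy, with stated times of 2 s and 20 s, tested at 750 nM; on this read-out lower numbers stand for less inhibition and higher numbers for more inhibition at the one concentration tested (going by the name of the read-out). Compound 1 `O=C1Nc2ccc(C(=O)c3ccco3)cc2/C1=C/c1cc(I)c(O)c(I)c1` carries a 4-hydroxy-3,5-diiodophenyl group and gives 26% in this assay . Compound 2 `O=C1Nc2ccc(C(=O)c3ccco3)cc2/C1=C/c1ccnc(Cl)c1` carries a 2-chloropyridin-4-yl group in the same place and gives 15.8%. Among the compounds with values here, the single measured step is a number 10.2 percentage points lower from compound 1 to compound 2 (beyond the scatter). Within the data shown here, compound 2 therefore stands lowest of the two numbers, its only neighbour being compound 1, a number higher by a margin beyond the scatter.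

Compound 3 `O=C1Nc2ccc(C(=O)c3ccco3)cc2/C1=C/c1ccc(O)c(Br)c1` is not yet measured. Its difference from compound 2 is 3-bromo-4-hydroxyphenyl in place of 2-chloropyridin-4-yl on a double-bonded chain carbon bound to a double-bonded ring carbon. Among the measured compounds shown here, the one measured step bears on this change, because a number 10.2 percentage points lower from compound 1 to compound 2 (beyond the scatter) ran from a hydroxyphenyl group bearing two iodines to the chloropyridinyl group, while compound 3 returns to a hydroxyphenyl group bearing one bromine. Compound 1 with 26% is thus the closer reference. The expected step is a number 7.2 percentage points higher from compound 2 to compound 3 (within the scatter), roughly the size of the measured step and in the opposite direction, though the scatter leaves its direction uncertain. Compound 3 is estimated at 23%, with a range from 10% to 36%.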

Compound 3, a percentage reported as inhibition, at one concentration (the size of the read-out at that concentration, not a potency): 23%
The estimate for compound 3 equals the measured number at the digits printed; low and high end bracket the measured number.
By their numbers in this assay, from the lowest: compounds 2, 3 and 1 (each within the scatter of the next, the first and the last beyond it).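

In this assay, the 3-bromo-4-hydroxyphenyl group of compound 3 cannot be told apart from either earlier group at this position, on a double-bonded chain carbon bound to a double-bonded ring carbon: the reading is a number 7.2 percentage points higher from compound 2 to compound 3 (within the scatter), and a number 3 percentage points lower from compound 1 to compound 3 (within the scatter). Within the data shown here, the single step beyond the scatter, between compound 1 and compound 2, therefore no longer divides the series into two separate levels, since compound 3 lies within the scatter of both and gives no clear effect of exchanging the two iodines of compound 1 for one bromine. No measurement at hand bears on the cause of these numbers.

The compounds shown leave open whether the hydroxyl group or the halogen on the phenyl ring matters here, a question that a plain 4-hydroxyphenyl group and a 3-bromophenyl group would separate. Also open is how an amine or a carboxylic acid in this place would read, and how any of these compounds would behave at other concentrations, since a single concentration gives no potency.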